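Cytotoxicity limits and a larger group on nitrogen

The source may report more compounds than this note shows. Statements on the series, on what has been measured and on what is new or still open speak of the compounds shown alone.

Compound 1 (`CCNc1n[n+]([O-])c2cc(C)c(OC)cc2[n+]1[O-]`) gives > 100 ug/mL as a limit
Compound 2 (`COc1cc2c(cc1C)[n+]([O-])nc(NC1CCC1)[n+]2[O-]`) gives > 50 ug/mL as a limit

Both entries come from an ADME assay on Vero cells (Chlorocebus sabaeus) for cytotoxicity, read by CellTiter-Glo, with a stated time of 72 h (a lower number here means that less compound is tolerated, a higher number that more compound is tolerated), and neither is an exact number. Compound 2 therefore has no measured position, and its > 50 ug/mL is only a limit. Within the data shown here, the one measured step, a step that the two limits leave unreadable from compound 1 to compound 2, places cyclobutyl where ethyl stood on a nitrogen on an aromatic ring. Its size cannot be read, so it offers no number to carry forward.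

Compound 3 (`COc1cc2c(cc1C)[n+]([O-])nc(N[C@@H]1C[C@H]3CC[C@@H]1C3)[n+]2[O-]`) keeps the shared core of compound 2 and changes the group on that same nitrogen (a group of 7 heavy atoms (7 carbon; 2 five-membered non-aromatic rings of carbon only) in place of a group of 4 heavy atoms (4 carbon; one four-membered non-aromatic ring of carbon only), on a nitrogen on an aromatic ring). This new group is clearly larger than the ones compared so far, and the unreadable step gives no sign of what that does in this assay.

The expected step of a number no higher from compound 2 to compound 3 (the limit leaves the size open) is estimated to stay within the usual scatter, with no firm direction. For compound 3 the estimated value is 50 ug/mL, with an expected range of 20 ug/mL to 100 ug/mL and a fair chance that the reading is again only a limit.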

Compound 3, half-maximal cytotoxic concentration: > 50 ug/mL
Compound 3 gave a limit, no number; the forecaster's own chance of this, stated with the estimate: 60%; the middle value sits exactly at the limit.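

In this assay compound 3 gives > 50 ug/mL, which is a limit and not a number. None of the steps linking compound 1, compound 2 and compound 3 can be read. The actual tolerated concentration of each of these compounds stays open, as does whether swapping the group on the nitrogen changes it at all.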